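The compounds below may be only part of what the source reports. "The series", "measured", "known", "first", "only" and "open" are said of these compounds alone.

Measured in an in vitro ADME assay on microsomes (Mus musculus) for metabolic stability (a lower number here means that the compound disappears faster, a higher number that the compound lasts longer), all three values being limits and not numbers:

- compound 1 `O=C(Nc1ccc(-c2nc(N3CC4CCC(C3)O4)c3cnn(C4CCC5(CC4)OCCO5)c3n2)cc1)Nc1cccnc1` gives > 0.5 h (limit)
- compound 2 `O=C(Nc1ccncc1)Nc1ccc(-c2nc(N3CC4CCC(C3)O4)c3cnn(C4CCC5(CC4)OCCO5)c3n2)cc1` gives > 0.5 h (limit)
- compound 3 `CNC(=O)Nc1ccc(-c2nc(N3CC4CCC(C3)O4)c3cnn(C4CCC5(CC4)OCCCO5)c3n2)cc1` gives > 0.5 h (limit)

Compound 2 has no numerical position in the series. Compound 2 stands at > 0.5 h and this is a limit. The same holds for the other two compounds, as the summary shows: the limit of > 0.5 h in this assay, at which 3 of the 3 values shown sit, is the whole of the picture so far.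

Compound 4 `O=C(Nc1ccc(-c2nc(N3CC4CCC(C3)O4)c3cnn(C4CCC5(CC4)OCCO5)c3n2)cc1)NC1CC1` carries cyclopropyl in place of pyridin-4-yl on an amide-type nitrogen and so exchanges a six-membered aromatic ring with one hetero atom for a three-membered non-aromatic ring of carbon only.

The nearest measured change at this place is a step that the two limits leave unreadable from compound 1 to compound 2 and it gives no size to carry over. It also concerns only a swap between two pyridinyl groups. For the measured compounds named here, no measured step therefore speaks for a direction, and no step beyond the usual scatter is expected. The expected change is a step that the limit leaves unreadable from compound 2 to compound 4 and it remains an estimate. The most likely outcome is another limit in this assay for compound 4. As a number, compound 4 is estimated at 0.7 h with an expected range from 0.35 h to 1.5 h in this read-out.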

Compound 4, half-life: 0.417 h
Compound 4: the middle estimate sits 1.7-fold (0.22 log units) above what was measured; low and high end bracket the measured number.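

In this assay, for the compounds shown here, compound 4, with cyclopropyl on the amide-type nitrogen, gives 0.417 h, the only value so far that is a number and not a limit. This gives the position its first readable steps, both for a three-membered non-aromatic ring of carbon only in place of a pyridinyl ring: an at least 1.1-fold lower number from compound 2 to compound 4 (0.07 log units; that floor lies within the scatter) and an at least 1.1-fold lower number from compound 1 to compound 4 (0.07 log units; that floor lies within the scatter). Going by these compounds alone, each step is a floor and not a size, so the result sets no firm direction for this change, and the single number stands against a series otherwise defined by a limit: the limit of > 0.5 h in this assay, at which 3 of the 4 values shown sit.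

Going by these compounds, the true distance of compound 1 and compound 2 from compound 4 remains unknown, and the step between compound 1 and compound 2 cannot be read, so the pyridin-3-yl and pyridin-4-yl groups cannot be ranked against each other. Also open, on these data alone, is what an isopropyl group, a longer alkyl chain or a chain ending in an amine would give on this nitrogen in this assay.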